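Aryl swap on the amine nitrogen: acid dissociation notes

A few compounds are considered here, and "the series" means these few. Any claim that something is new, unique, unknown or untested is made for them only; others in the source may bear on it.

Measured compounds:
compound 1 `COc1ccc(CN(CCN(C)C)c2ccccc2)cc1` — 9.7
compound 2 `COc1ccc(CN(CCN(C)C)c2ccc(N)cc2)cc1` — 9.8
compound 3 `COc1ccc(CN(CCN(C)C)c2ccc(C)cc2)cc1` — 9.8

In a physicochemical assay for acid dissociation, compound 2 stands level with compound 3 at the digits shown, the two together the highest of the three numbers; its furthest neighbour is compound 1, and that gap, a number 0.10 log units higher from compound 1 to compound 2 (within the scatter), lies within the scatter. Likewise a number 0.10 log units higher from compound 1 to compound 3 (within the scatter) and no change at the digits printed from compound 2 to compound 3 (within the scatter) are within the scatter, so across these three compounds substitution on the aryl ring carried by the amine nitrogen has not moved the read-out beyond noise.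

Compound 4 `COc1ccc(CN(CCN(C)C)c2ccc(N)cn2)cc1` is not yet measured. Its change from compound 2 is 5-aminopyridin-2-yl in place of 4-aminophenyl on an amine nitrogen. For the measured compounds named here, no measured step covers a ring carbon exchanged for ring nitrogen; the two steps that touch the same aryl ring, from compound 1 to compound 2 and from compound 1 to compound 3, were both small. On that basis the step is expected to stay within the scatter or to be only slightly downward, a number 0.20 log units lower from compound 2 to compound 4 (within the scatter). Compound 4 is therefore estimated at 9.6, with a range from 9.2 to 10.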

Compound 4, acid dissociation constant: 9.4
For compound 4 the middle estimate is 0.20 log units above the measured one; low and high end bracket the measured number.
By their numbers in this assay, from the lowest: compounds 4, 1, 2 and 3 (each within the scatter of the next, the first and the last beyond it).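

In this assay, changing the aryl group on the amine nitrogen now gives steps beyond the scatter, with a number 0.40 log units lower from compound 2 to compound 4 (beyond the scatter) and a number 0.40 log units lower from compound 3 to compound 4 (beyond the scatter) both modest. The phenyl comparison is less clear, since a number 0.30 log units lower from compound 1 to compound 4 (within the scatter) remains within the scatter, so the change to 5-aminopyridin-2-yl separates compound 4 from the two substituted phenyl compounds but not from compound 1. No measurement available here bears on why the number differs.

The compounds shown leave open whether the step follows the ring nitrogen alone or its combination with the amino group. An unsubstituted pyridin-2-yl group or a methyl-substituted pyridin-2-yl group on the same amine nitrogen would separate those two readings.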